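Swapping a Phenol for a Methyl Carbamate

The source may report more compounds than this note shows. Statements on the series, on what has been measured and on what is new or still open speak of the compounds shown alone.

Of the compounds shown here, three have been measured in an assay on isolated protein for binding affinity to Alpha-1D adrenergic receptor (Rattus norvegicus), read by radioligand binding; on this read-out higher numbers stand for weaker inhibition and lower numbers for stronger inhibition. Compound 1, `Oc1cccc2c1CCCC2c1c[nH]cn1`, gives 30.9 nM in this assay, the lowest of the two plain numbers recorded. Compound 3, `CCS(=O)(=O)Nc1cccc(NC2=NCCN2)c1`, gives 355 nM in this assay, a higher number than compound 1 by a margin that is beyond the usual scatter of repeated measurements. Compound 2, `CCS(=O)(=O)Nc1cccc2c1CCCC2(O)c1c[nH]cn1`, returns only a limit of the assay, < 10000 nM, rather than a number.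

The next compound, compound 4, `COC(=O)Nc1cccc2c1CCCC2c1c[nH]cn1`, has not been measured yet. It differs from compound 1 in one place: (methoxycarbonyl)amino in place of hydroxy on an aromatic carbon. Going by the values given here, no measured pair shows this exact change, so its effect can only be anticipated. Compound 2 and compound 3 carry other groups on their aromatic rings and do not settle the question. The expectation is a modest weakening, a step of a 3.2-fold higher number from compound 1 to compound 4 (0.51 log units; beyond the scatter) from compound 1 to compound 4 in this assay. Compound 4 is therefore estimated to give 100 nM in this assay, within a range from 20 nM to 600 nM.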

Compound 4, inhibition constant: 3020 nM
For compound 4 the middle estimate is 30-fold (1.48 log units) below the measured one, outside the stated range (above it).
By their numbers in this assay, from the lowest: compound 1; then compound 3; then compound 4.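

In this assay, going by these compounds alone, a 98-fold higher number from compound 1 to compound 4 (1.99 log units; beyond the scatter) is large, and it is the first reading of a single change at this position, since the earlier compounds differ from compound 1 in more than one place. This aromatic carbon, ortho to a fused ring and meta to a fused ring, holds the hydroxy of compound 1, and on the shared core, replacing that group of 1 heavy atom with the (methoxycarbonyl)amino group of 5 heavy atoms costs much of the binding. Both groups count 1 hydrogen-bond donor, so keeping that count does not by itself keep the binding.

A plain amine or a methoxy group at this carbon would help separate the part played by the nitrogen from that of the carbonyl and the methyl end. Nothing among the results shown accounts for the size of this step.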